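Nitrile in place of the diamine on the chain

A few compounds are considered here, and "the series" means these few. Any claim that something is new, unique, unknown or untested is made for them only; others in the source may bear on it.

The set rests on the shared core of compound 1 `CCCc1c[nH]c2ccc(F)cc12`. In an assay on isolated protein for inhibition of Myeloperoxidase (Homo sapiens), read by ELISA, with a stated time of 5 min (a lower number here means a stronger inhibitor, a higher number a weaker inhibitor), compound 1 gives > 100 nM, which is a limit of the assay and not a number. Compound 2 `N#CSCCCc1c[nH]c2ccc(F)cc12` gives 23 nM in this assay, and compound 3 `NCC(N)CCc1c[nH]c2ccc(F)cc12` gives 26 nM. Compound 3 thus carries the higher of the two numbers, but the step of a 1.1-fold higher number from compound 2 to compound 3 (0.05 log units; within the scatter) lies within the scatter. The steps of an at least 4.3-fold lower number from compound 1 to compound 2 (0.63 log units; beyond the scatter) and an at least 3.8-fold lower number from compound 1 to compound 3 (0.58 log units; beyond the scatter) both run beyond the scatter, so either group on the chain lowers the number against the bare propyl chain.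

Compound 4 `N#CCCCc1c[nH]c2ccc(F)cc12` differs from compound 3 by cyanomethyl in place of 1,2-diaminoethyl on a saturated chain carbon, two bonds along the chain from an aromatic carbon. Going by the values given here, no measured step carries a cyanomethyl group, so the bearing steps are indirect: the chain of compound 4 sits between the bare propyl chain of compound 1 and the cyanosulfanyl chain of compound 2. Compound 4 is therefore expected to land in between, with the step of a 3.5-fold higher number from compound 3 to compound 4 (0.54 log units; beyond the scatter) estimated as a modest rise. The estimate for compound 4 in this assay is 90 nM, ranging from 20 nM to 400 nM.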

Compound 4, half-maximal inhibitory concentration: 72 nM
The estimate for compound 4 lay 1.3-fold (0.10 log units) above the measured number, within the range that was stated.
By their numbers in this assay, from the lowest: compounds 2 and 3 (each within the scatter of the next); then compound 4. At a limit, above all of these: compound 1.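

In this assay, the 2-cyanoethyl chain of compound 4 does not match the two chains that gave indistinguishable numbers earlier: a 2.8-fold higher number from compound 3 to compound 4 (0.44 log units; beyond the scatter) and a 3.1-fold higher number from compound 2 to compound 4 (0.50 log units; beyond the scatter) both run beyond the scatter, although modestly. So this position does not treat every group placed there alike, and a nitrile on the chain does not by itself reach the level of compound 2, which carries cyanosulfanyl in place of cyano. The remaining step, an at least 1.3-fold lower number from compound 1 to compound 4 (0.14 log units; that floor lies within the scatter), cannot be read as a change, because its starting value is a limit of the assay and not a number: the limit of > 100 nM in this assay, at which 1 of the 4 values shown sits.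

What the compounds shown leave open is whether a nitrile on this chain lowers the number at all against the bare propyl chain. They also leave open whether a single amine, or a carboxylic acid, on the same chain would fall nearer compound 3 or compound 4.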